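This account rests on a few compounds, and the source may have more. Where it says the series, first, only, none or still open, it means among the compounds named here.

Three compounds share the same core and differ only in the group on an amine nitrogen in a ring. Compound 1 `CCCCCC(=O)c1ccc(OCCCN2CCN(C(=O)N3CCOCC3)CC2)cc1` carries a (morpholin-4-yl)carbonyl group there, and in an assay on isolated protein for binding affinity to histamine H2 receptor (Homo sapiens) (a higher number here means a weaker inhibitor, a lower number a stronger inhibitor), compound 1 gives 17800 nM. Compound 2 `CCCCCC(=O)c1ccc(OCCCN2CCN(S(=O)(=O)c3ccc(C#N)cc3)CC2)cc1` carries a (4-cyanophenyl)sulfonyl group, and in this assay compound 2 gives 12300 nM. Compound 3 `CCCCCC(=O)c1ccc(OCCCN2CCN(C(=O)c3c[nH]cn3)CC2)cc1` carries a (1H-imidazol-4-yl)carbonyl group, and in this assay compound 3 gives 19500 nM. Compound 2 has the lowest of the three numbers, yet a 1.4-fold lower number from compound 1 to compound 2 (0.16 log units; within the scatter) and a 1.6-fold higher number from compound 2 to compound 3 (0.20 log units; within the scatter), so all three values sit within the usual scatter of one another; likewise a 1.1-fold higher number from compound 1 to compound 3 (0.04 log units; within the scatter).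

Compound 4 `CCCCCC(=O)c1ccc(OCCCN2CCN(C(=O)C3CCC3)CC2)cc1` has not yet been measured. The change from compound 2 is cyclobutylcarbonyl in place of (4-cyanophenyl)sulfonyl on an amine nitrogen in a ring. The two steps that alter the same ring nitrogen bear on this change: the step from compound 1 to compound 2 and the step from compound 2 to compound 3 both stayed within the scatter. Exchanging the group on that nitrogen has so far moved the numbers very little. For compound 4 a step of a 1.2-fold higher number from compound 2 to compound 4 (0.09 log units; within the scatter) is therefore expected, meaning no change beyond the scatter. Compound 4 is estimated at 15000 nM in this assay, with a range from 6000 nM to 40000 nM.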

Compound 4, inhibition constant: 10200 nM
Compound 4: the middle estimate sits 1.5-fold (0.17 log units) above what was measured; measured number inside the range.
By their numbers in this assay, from the lowest: compounds 4, 2, 1 and 3 (each within the scatter of the next).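

Cyclobutylcarbonyl is the first group on this amine nitrogen whose ring holds carbon only and is not aromatic, and the change from the (4-cyanophenyl)sulfonyl group gives a 1.2-fold lower number from compound 2 to compound 4 (0.08 log units; within the scatter) in this assay. At the carbonyl carbon itself, cyclobutyl in place of morpholin-4-yl gives a 1.7-fold lower number from compound 1 to compound 4 (0.24 log units; within the scatter), and cyclobutyl in place of 1H-imidazol-4-yl gives a 1.9-fold lower number from compound 3 to compound 4 (0.28 log units; within the scatter), so a carbon-only ring, a ring with oxygen and nitrogen, and an aromatic ring with two nitrogens all leave the number inside the scatter at this position. Nothing among the data shown offers an explanation for this flat picture.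

As far as these compounds go, all four groups reach the nitrogen through a carbonyl or a sulfonyl, so it remains open whether a group joined directly through carbon, such as benzyl or a simple methyl, would move the number in this assay beyond the scatter. From the compounds shown here alone, it also remains open whether a carbonyl group carrying a carboxylic acid or a longer chain ending in an amine would do so.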